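Chloro for hydrogen on the ring nitrogen carrier: permeability

A few compounds are considered here, and "the series" means these few. Any claim that something is new, unique, unknown or untested is made for them only; others in the source may bear on it.

Measured so far:
compound 1 `CCCCc1[nH]c(=O)c(S(=O)(=O)c2ccc(-c3ccncc3C)cc2)c(O)c1-c1c(OC)cccc1OC` gives 76 nm/s in an ADME assay for permeability, using PAMPA, at pH 7.4; a higher number here means that the compound crosses the layer faster, a lower number that the compound crosses the layer more slowly
compound 2 `CCCCc1[nH]c(=O)c(S(=O)(=O)c2ccc(-n3ccccc3=O)cc2)c(O)c1-c1c(OC)cccc1OC` gives 5 nm/s

For the measured compounds named here, compound 2 stands lowest of the two numbers in this assay; the only measured step is a 15-fold lower number from compound 1 to compound 2 (1.18 log units; beyond the scatter). Compound 3 `CCCCc1[nH]c(=O)c(S(=O)(=O)c2ccc(-n3cc(Cl)ccc3=O)cc2)c(O)c1-c1c(OC)cccc1OC` differs from compound 2 by chloro in place of hydrogen on an aromatic carbon. Going by the values given here, no measured step covers this change; the step from compound 1 to compound 2 exchanges a whole ring and gives no guide for a single chloro. A small step is therefore expected, a 1.8-fold higher number from compound 2 to compound 3 (0.26 log units; within the scatter), with no clear direction beyond the scatter. Compound 3 is estimated at 9 nm/s, ranging from 3 nm/s to 30 nm/s.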

Compound 3, apparent permeability: 22 nm/s
The estimate for compound 3 lay 2.4-fold (0.39 log units) below the measured number; low and high end bracket the measured number.
By their numbers in this assay, from the lowest: compound 2; then compound 3; then compound 1.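

In this assay, chloro in place of hydrogen on an aromatic carbon, two atoms from the ring nitrogen, gives a 4.4-fold higher number from compound 2 to compound 3 (0.64 log units; beyond the scatter) and shows that a single heavy atom at this position can move the number beyond the scatter. Part of the gap left by the ring exchange closes, but a 3.5-fold lower number from compound 1 to compound 3 (0.54 log units; beyond the scatter) still stands against the ring of compound 1. No measurement shown bears on the reason for this step.
As far as these compounds go, whether fluoro, methyl or a nitrile at this carbon moves the number in the same way remains open. So does whether chloro on another carbon of this ring has a similar effect.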